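This account rests on a few compounds, and the source may have more. Where it says the series, first, only, none or still open, it means among the compounds named here.

Measured in a functional assay on MCF7 cells (Homo sapiens) for cytotoxicity, read by MTT assay, with a stated time of 72 h; on this read-out lower numbers stand for stronger inhibition and higher numbers for weaker inhibition:

compound 1 `O=C1c2c[n+]([O-])c3ccccc3c2C(=O)c2c1c1ccccc1n2CCCCn1ccnc1` gives 130 nM
compound 2 `CN1CCN(CCCCn2c3c(c4ccccc42)C(=O)c2c[n+]([O-])c4ccccc4c2C3=O)CC1` gives 100 nM
compound 3 `O=C1c2c[n+]([O-])c3ccccc3c2C(=O)c2c1c1ccccc1n2CCN1CCCCC1` gives 620 nM

Of the three, compound 3 has the highest number at 620 nM, and its gaps to both others lie beyond the scatter. The step under consideration leads to compound 4 `CN(C)CCCCn1c2c(c3ccccc31)C(=O)c1c[n+]([O-])c3ccccc3c1C2=O` and reads (2-(dimethylamino)ethyl in place of piperidin-1-yl on a saturated chain carbon, two bonds along the chain from an aromatic nitrogen). Cut one bond further out, this is 2-(piperidin-1-yl)ethyl to 4-(dimethylamino)butyl. Compound 4 therefore resembles compounds 1 and 2 in carrying its end group four bonds along the chain from an aromatic nitrogen.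

For the measured compounds named here, two measured steps bear most directly on the change: a 4.8-fold higher number from compound 1 to compound 3 (0.68 log units; beyond the scatter) and a 6.2-fold higher number from compound 2 to compound 3 (0.79 log units; beyond the scatter). Both are modest. A third, a 1.3-fold lower number from compound 1 to compound 2 (0.11 log units; within the scatter), shows that these two different end groups give values within the scatter at that chain position. Going by the values given here, no compound with a dimethylamino end group has been measured, and no pair separates the end group from the chain change, so the expectation is tentative.

A modest step to a lower number is expected, roughly reversing those two steps. The expected change is a 4.1-fold lower number from compound 3 to compound 4 (0.62 log units; beyond the scatter). For compound 4 the estimated value is 150 nM, with an expected range of 60 nM to 400 nM.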

Compound 4, half-maximal inhibitory concentration: 220 nM
Beside the measured number, compound 4's estimate is 1.5-fold (0.17 log units) below it; low and high end bracket the measured number.
By their numbers in this assay, from the lowest: compounds 2, 1 and 4 (each within the scatter of the next, the first and the last beyond it); then compound 3.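

In this assay, replacing 2-(piperidin-1-yl)ethyl with 4-(dimethylamino)butyl gives a 2.8-fold lower number from compound 3 to compound 4 (0.45 log units; beyond the scatter), so an end group with no ring, carried four bonds along the chain from the aromatic nitrogen, also lies on the low-number side of compound 3. Variation among end groups at this chain position now exceeds the scatter in one comparison: dimethylamino in place of 4-methylpiperazin-1-yl gives a 2.2-fold higher number from compound 2 to compound 4 (0.34 log units; beyond the scatter), whereas dimethylamino in place of 1H-imidazol-1-yl gives a 1.7-fold higher number from compound 1 to compound 4 (0.23 log units; within the scatter). No supporting data are available to account for these differences.

End group and chain length change together in the step to compound 4, so the compounds shown do not assign its size to either change. A 4-(piperidin-1-yl)butyl or 2-(dimethylamino)ethyl chain on the shared core would separate the two contributions, while a morpholin-4-yl end group on the butyl chain would test whether the difference between the dimethylamino and 4-methylpiperazin-1-yl end groups extends to another saturated amine.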